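Lengthening the Unsaturated Amide Chain: An Expected Outcome

The compounds below may be only part of what the source reports. "The series", "measured", "known", "first", "only" and "open" are said of these compounds alone.

Measured compounds:
- compound 1, `CC/C=C/C(=O)Nc1cc2c(N3CCc4ccccc43)ncnc2cc1OC`: 2470 nM
- compound 2, `COc1cc2ncnc(N3CCc4ccccc43)c2cc1NC(=O)/C=C/C(C)C`: 6410 nM
- compound 3, `C/C=C/C(=O)Nc1cc2c(N3CCCc4ccccc43)ncnc2cc1O[C@@H]1CCOC1`: 10800 nM

All three were tested in a functional assay on A549 cells (Homo sapiens) for antiproliferative activity, read by MTT assay, with a stated time of 72 h; a higher number here means a weaker inhibitor, a lower number a stronger inhibitor. Compound 1 gives 2470 nM, and compound 2, which carries methyl in place of hydrogen on a saturated chain carbon bound to a double-bonded chain carbon and a saturated chain carbon, gives 6410 nM. The resulting change is a 2.6-fold higher number from compound 1 to compound 2 (0.41 log units; beyond the scatter). Compound 3 gives 10800 nM; its number and that of compound 2 lie within the usual scatter of each other, so no order can be read between them, while the gap to compound 1 is beyond the scatter.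

Compound 4, `CC/C=C/C(=O)Nc1cc2c(N3CCCc4ccccc43)ncnc2cc1O[C@@H]1CCOC1`, is not yet measured. It differs from compound 3 by methyl in place of hydrogen on a saturated chain carbon bound to a double-bonded chain carbon. Within the data shown here, this is the same kind of change as the one from compound 1 to compound 2, but not the same: in compound 2 the new methyl sits on a saturated chain carbon bound to a double-bonded chain carbon and a saturated chain carbon, whereas in compound 4 it sits on a saturated chain carbon bound to a double-bonded chain carbon only. The difference between the core of compound 1 and the core of compound 3 is not broken down here.

Among the measured compounds shown here, for compound 4 in this assay the expected step is a 1.5-fold higher number from compound 3 to compound 4 (0.17 log units; within the scatter), a modest weakening estimated by analogy with the step of a 2.6-fold higher number from compound 1 to compound 2 (0.41 log units; beyond the scatter), with wide uncertainty since only one example of this kind of change is available and its surroundings differ. Compound 4 is therefore estimated at 16000 nM, with a range from 6000 nM to 45000 nM.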

Compound 4, half-maximal inhibitory concentration: 14100 nM
The estimate for compound 4 lay 1.1-fold (0.05 log units) above the measured number; the measured number falls inside the stated range.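

In this assay, methyl in place of hydrogen on a saturated chain carbon bound to a double-bonded chain carbon gives a 1.3-fold higher number from compound 3 to compound 4 (0.12 log units; within the scatter), so on this core the step cannot be told apart from the ordinary spread of repeated measurements. Set beside the earlier step, the result gives no sign that the change behaves differently on the two cores: the same change on two cores in this assay, a 2.6-fold higher number (0.41 log units; beyond the scatter) from compound 1 to compound 2 and a 1.3-fold higher number (0.12 log units; within the scatter) from compound 3 to compound 4, 2.0-fold (0.30 log units) apart, within the scatter of two such steps. Among these compounds, this does not prove that the change carries over unaltered: the earlier step lies beyond the scatter while the new one lies within it, each core offers only a single pair, and the added methyl does not sit on the same kind of carbon in the two pairs.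

Compound 1 and compound 4 carry the same but-1-en-1-yl chain but differ elsewhere in more than one place, so the compounds shown leave open how much each of those differences contributes on its own. Also open, as far as these compounds go, is how the two cores would respond to a larger alteration of the unsaturated amide chain, such as a longer chain or an amine.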